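Series notes: piperidine carboxamide coumarin ethers, tolerability on A549

The compounds below may be only part of what the source reports. "The series", "measured", "known", "first", "only" and "open" are said of these compounds alone.

Of the compounds shown here, two have been measured so far. Compound 1 `Cc1c(Cc2ccc(C(F)(F)F)cc2)c(=O)oc2cc(OCC(O)CN3CCC(C(N)=O)CC3)ccc12` gives 89300 nM in an ADME assay on A549 cells (Homo sapiens) for cytotoxicity, read by CellTiter-Glo; a lower number here means that less compound is tolerated, a higher number that more compound is tolerated. Compound 2 `Cc1c(Cc2ccccc2)c(=O)oc2cc(OCC(CN3CCC(C(N)=O)CC3)Oc3ccc(F)cc3)ccc12` gives 66400 nM in this assay; the two numbers differ by less than the usual scatter of the assay, so compound 2 and compound 1 are not distinguishable on these data, and neither can be called better or worse tolerated.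

The next compound, compound 3 `Cc1c(Cc2ccccc2)c(=O)oc2cc(OCC(CN3CCC(C(N)=O)CC3)Oc3ccc(-c4ncc(N)s4)cc3)ccc12`, differs from compound 2 at a single position: 5-amino-1,3-thiazol-2-yl in place of fluoro on an aromatic carbon. Within the data shown here, no step between measured compounds covers a change of this kind, so there is no measured precedent for what the 5-amino-1,3-thiazol-2-yl group does in this assay.

With the two measured values sitting close together, the working expectation for compound 3 is a modest move toward a lower number, estimated as a 1.7-fold lower number from compound 2 to compound 3 (0.22 log units; within the scatter), but a result within the scatter of compound 2 would not be surprising. Compound 3 is therefore expected to give about 40000 nM in this assay, with a plausible range from 15000 nM to 110000 nM.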

Compound 3, half-maximal cytotoxic concentration: > 100000 nM
Compound 3 ended at the assay's limit; the forecaster's own chance of this, stated with the estimate: 15%; at least 2.5-fold (0.39 log units) between middle value and limit.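

Among these compounds, this position is the first where a change can be read on its own. In this assay compound 3 gives > 100000 nM, which is a limit of the assay and not a number. Placing 5-amino-1,3-thiazol-2-yl in place of fluoro on the aromatic carbon para to a large group gives an at least 1.5-fold higher number from compound 2 to compound 3 (0.17 log units; that floor lies within the scatter), so this aromatic carbon carries a five-membered aromatic ring with 2 hetero atoms with no sign of a lower number, and the true size of the step stays unknown because the reading stops at the limit: the limit of > 100000 nM in this assay, at which 1 of the 3 values shown sits.

The compounds shown leave open how a plain amine, a carboxylic acid or an unsubstituted phenyl at this aromatic carbon would read in this assay, and whether the amino group of the 5-amino-1,3-thiazol-2-yl group plays any part in the result. They also leave open whether the same replacement would read the same way with a trifluoromethyl on the benzyl group of the shared core.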